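Chlorophenyl swap in a hydrazide sulfonamide series

The source may hold more compounds than are shown below. What is called first, only, known or untested is meant among the compounds shown, and "the series" means these compounds.

Measured so far in a functional assay on A549 cells (Homo sapiens) for antiproliferative activity, read by MTT assay, with a stated time of 24 h; a higher number here means a weaker inhibitor, a lower number a stronger inhibitor:

compound 1 `O=C(NNc1ccccc1Cl)c1ccc(NS(=O)(=O)c2cnc(O)nc2O)cc1`: 3340 nM
compound 2 `O=C(NNc1cccc(Cl)c1)c1ccc(NS(=O)(=O)c2cnc(O)nc2O)cc1`: 7290 nM
compound 3 `O=C(NNc1ccccc1Cl)c1cccc(NS(=O)(=O)c2cnc(O)nc2O)c1`: 1460 nM

Compound 1 and compound 2 differ by 3-chlorophenyl in place of 2-chlorophenyl on an amine nitrogen. That single change gave a 2.2-fold higher number from compound 1 to compound 2 (0.34 log units; beyond the scatter), so in this pair the 3-chlorophenyl compound reads weaker than the 2-chlorophenyl one. Compound 3 holds the lowest number of the three; how its core differs from that of compound 1 is not broken down here, and the two values are simply compared as they stand.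

Compound 4 `O=C(NNc1cccc(Cl)c1)c1cccc(NS(=O)(=O)c2cnc(O)nc2O)c1` is the unmeasured partner of compound 3. It differs from compound 3 by 3-chlorophenyl in place of 2-chlorophenyl on an amine nitrogen, the same change as between compound 1 and compound 2, at the same place in each pair. The expected step of a 2.2-fold higher number from compound 3 to compound 4 (0.34 log units; beyond the scatter) in this assay rests on the one earlier observation, a 2.2-fold higher number from compound 1 to compound 2 (0.34 log units; beyond the scatter), and carries the uncertainty of a single precedent on a different core. Compound 4 is therefore estimated at 3200 nM in this assay, with a plausible range from 1500 nM to 7000 nM.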

Compound 4, half-maximal inhibitory concentration: 6640 nM
Compound 4: the middle estimate sits 2.1-fold (0.32 log units) below what was measured; low and high end bracket the measured number.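

In this assay, 3-chlorophenyl in place of 2-chlorophenyl on an amine nitrogen gave a 4.5-fold higher number from compound 3 to compound 4 (0.66 log units; beyond the scatter), the same direction as the earlier step on the core of compound 1. Set side by side, the two steps cannot be told apart in size: the same change on two cores in this assay, a 2.2-fold higher number (0.34 log units; beyond the scatter) from compound 1 to compound 2 and a 4.5-fold higher number (0.66 log units; beyond the scatter) from compound 3 to compound 4, 2.1-fold (0.32 log units) apart, within the scatter of two such steps The change therefore carried over in direction on these two cores, with no sign that its size depends on the core, but two pairs do not show that it would hold on any further core, and they do not explain why the 2-chlorophenyl compounds give the lower numbers.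

Still open, on these data alone, is how a plain phenyl, a fluorophenyl or a methoxyphenyl on the same amine nitrogen would read on either core. Also open, as far as these compounds go, is whether the same order of the two chlorophenyl groups would appear in other cell lines or with other exposure times.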